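Swapping the amide aryl group on a pyrazole-amide receptor modulator

The source may report more compounds than this note shows. Statements on the series, on what has been measured and on what is new or still open speak of the compounds shown alone.

Measured compounds:
Compound 1, `O=C(Nc1ccc(Br)cc1CN1C(=O)c2ccccc2C1=O)c1ccccn1`, 740 nM
Compound 2, `O=C(Nc1cc(-c2ccccc2)nn1-c1ccccc1)c1cccc(Cl)c1`, 40 nM

Both compounds were tested in an assay on CHO cells with metabotropic glutamate receptor 5 (Homo sapiens) as the target; on this read-out lower numbers stand for an effect already at smaller amounts and higher numbers for an effect only at larger amounts of compound. Compound 1 gives 740 nM in this assay, while compound 2 gives 40 nM. Of the two numbers, compound 2 has the lower one, and the gap between the two compounds is well beyond the usual scatter of repeated measurements, so compound 2 is the more potent of this pair.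

Compound 3, `O=C(Nc1cc(-c2ccccc2)nn1-c1ccccc1)c1ccccc1O`, has not yet been measured. It keeps the shared core of compound 2 and differs in one place: 2-hydroxyphenyl in place of 3-chlorophenyl on a carbonyl carbon. Within the data shown here, no measured pair shows what such a change does here, so the expectation rests on compound 2 alone. The change is expected to cost some potency, giving a step from compound 2 to compound 3 of a 3.8-fold higher number from compound 2 to compound 3 (0.57 log units; beyond the scatter) in this assay, a move towards a higher number that may or may not exceed the scatter. Compound 3 is estimated to give 150 nM in this assay, with a range from 40 nM to 600 nM.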

Compound 3, half-maximal effective concentration: > 10000 nM
Compound 3 was reported as a limit; the forecaster's own chance of this, stated with the estimate: 5%; at least 66-fold (1.82 log units) between middle value and limit.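

In this assay compound 3 gives > 10000 nM, which is a limit of the assay and not a number. With 2-hydroxyphenyl in place of 3-chlorophenyl on the carbonyl carbon, the result is an at least 250-fold higher number from compound 2 to compound 3 (2.39 log units; beyond the scatter), so the choice of group at this place matters greatly: both groups are six-membered aromatic rings of carbon only with the same count of heavy atoms, and that shared frame alone does not preserve the potency of compound 2. The true size of this step stays unknown because the reading for compound 3 stops at the limit: the limit of > 10000 nM in this assay, at which 1 of the 3 values shown sits.

This one swap changes both the substituent, chlorine for hydroxyl, and the number that marks its place in the group's name, so the compounds shown cannot say which of the two changes matters. From the compounds shown here alone, a plain phenyl, 3-hydroxyphenyl or 2-chlorophenyl on the same carbonyl carbon would help separate these effects, and it also remains open whether a methoxy group would behave like the hydroxyl.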